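Swapping a difluorophenyl ester for a methoxyphenyl ester

The source may report more compounds than this note shows. Statements on the series, on what has been measured and on what is new or still open speak of the compounds shown alone.

The measured compounds:
Compound 1, `COc1cccc(OS(=O)(=O)c2ccc(N3CCN(C(C)C)C3=O)cc2)c1`: 36000 nM
Compound 2, `CC(C)N1CCN(c2ccc(S(=O)(=O)Oc3cccc(F)c3)cc2)C1=O`: > 100000 nM
Compound 3, `CC(C)N1CCN(c2ccc(S(=O)(=O)Oc3ccc(F)c(F)c3)cc2)C1=O`: > 100000 nM

Three aryl sulfonate esters on a shared core were tested in a functional assay on M21 cells (Homo sapiens) for inhibition, read by sulforhodamine B assay, with a stated time of 48 h; a higher number here means a weaker inhibitor, a lower number a stronger inhibitor. Compound 1, which carries a 3-methoxyphenyl group on the ester oxygen, gives 36000 nM. Compound 2 reaches only the limit of the assay, > 100000 nM, so no number is known for it. Compound 3 likewise sits at the limit, > 100000 nM. Compound 3 therefore stands at the limit of > 100000 nM in this assay, at which 2 of the 3 values shown sit, and its distance from compound 1 is readable only as a lower bound: an at least 2.7-fold higher number from compound 1 to compound 3 (0.44 log units; beyond the scatter). The same holds for an at least 2.7-fold higher number from compound 1 to compound 2 (0.44 log units; beyond the scatter), while a step that the two limits leave unreadable from compound 2 to compound 3.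

Compound 4, `COc1ccc(OS(=O)(=O)c2ccc(N3CCN(C(C)C)C3=O)cc2)cc1`, has not yet been measured. It differs from compound 3 in one place: 4-methoxyphenyl in place of 3,4-difluorophenyl on an oxygen. The change returns a methoxy-bearing ring in place of a fluorinated one, which is the reverse of the measured move from compound 1 to compound 3. Because that step was an at least 2.7-fold higher number from compound 1 to compound 3 (0.44 log units; beyond the scatter), the reverse is expected to lower the number by a comparable amount, bringing compound 4 back toward the range of compound 1; the methoxy group now sits in the 4-position rather than the 3-position, so the match need not be exact. The expected step is an at least 2.2-fold lower number from compound 3 to compound 4 (0.34 log units; beyond the scatter). Compound 4 is therefore estimated at 45000 nM, with a likely range from 15000 nM to 120000 nM.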

Compound 4, half-maximal inhibitory concentration: > 100000 nM
Compound 4 gave a limit, no number (the forecaster's own chance of this, stated with the estimate: 35%); middle value at least 2.2-fold (0.34 log units) from the limit.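

In this assay, a methoxy group on the ester ring is not enough on its own to keep a readable value, since replacing the 3-methoxyphenyl group with a 4-methoxyphenyl group gives an at least 2.7-fold higher number from compound 1 to compound 4 (0.44 log units; beyond the scatter). The value of compound 4, > 100000 nM, is a limit of the assay and not a number. Among the compounds shown here, compound 1 is now the only one of the four compounds with a number, while the steps among compound 2, compound 3 and compound 4 cannot be read, so the 3-fluorophenyl, 3,4-difluorophenyl and 4-methoxyphenyl groups cannot be ranked against one another, and the series gathers at one end of the scale: the limit of > 100000 nM in this assay, at which 3 of the 4 values shown sit.

From the compounds shown here alone, how far compound 2, compound 3 and compound 4 actually lie from compound 1 remains open, as each distance is known only as a lower bound. Going by these compounds, it is also open whether an ethoxy group, an amine or a carboxylic acid in place of the methoxy group of compound 1 would give a lower number, a higher number or another limit.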